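The source may hold more compounds than are shown below. What is called first, only, known or untested is meant among the compounds shown, and "the series" means these compounds.

Of the compounds shown here, three built on one shared core have been measured in an in vitro assay on CHO cells for displacement of a labelled ligand from Bombesin receptor subtype-3 (Homo sapiens), read by scintillation counting, with a stated time of 2 h; a lower number here means a stronger inhibitor, a higher number a weaker inhibitor. Compound 1 `CCC(C)(C)Cc1c[nH]c(CCc2ccc(-c3ccncc3)cc2)n1` gives 101 nM. Compound 2 `CCC(C)(C)Cc1c[nH]c(CCc2ccc(N3CCCCC3)cc2)n1`, which carries piperidin-1-yl in place of pyridin-4-yl, gives 28 nM, and compound 3 `CCC(C)(C)Cc1c[nH]c(CCc2ccc(-n3ccnn3)cc2)n1`, carrying 1H-1,2,3-triazol-1-yl on that aromatic carbon, gives 390 nM. Compound 1 thus stands second highest of the three, with a step of a 3.6-fold lower number from compound 1 to compound 2 (0.56 log units; beyond the scatter) on one side and a 3.9-fold higher number from compound 1 to compound 3 (0.59 log units; beyond the scatter) on the other.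

Compound 4 `CCC(C)(C)Cc1c[nH]c(CCc2ccc(-n3cccn3)cc2)n1` has not yet been measured. It differs from compound 1 in one place: 1H-pyrazol-1-yl in place of pyridin-4-yl on an aromatic carbon. Among the compounds with values here, the measured step that bears most directly on this change is the one to compound 3, where a five-membered aromatic ring with hetero atoms also replaced pyridin-4-yl and the number went up modestly. The step of a 14-fold higher number from compound 2 to compound 3 (1.14 log units; beyond the scatter) is large, but it starts from a different compound. A modest rise beyond the scatter is therefore expected, with the step from compound 1 to compound 4 estimated as a 2.0-fold higher number from compound 1 to compound 4 (0.30 log units; within the scatter). For compound 4 in this assay the estimate is 200 nM, with a range from 80 nM to 500 nM.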

Compound 4, half-maximal inhibitory concentration: 33 nM
The estimate for compound 4 lay 6.1-fold (0.78 log units) above the measured number, outside the stated range (below it).
By their numbers in this assay, from the lowest: compounds 2 and 4 (each within the scatter of the next); then compound 1; then compound 3.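

The five-membered aromatic rings at this place do not act alike: 1H-pyrazol-1-yl lowers the number relative to pyridin-4-yl (a 3.1-fold lower number from compound 1 to compound 4 (0.49 log units; beyond the scatter)), while 1H-1,2,3-triazol-1-yl raised it, so the direction of the change depends on which ring enters. Exchanging one of these related rings for the other produces a large step (a 12-fold lower number from compound 3 to compound 4 (1.07 log units; beyond the scatter)), and the 1H-pyrazol-1-yl compound lies within the scatter of the piperidin-1-yl compound (a 1.2-fold higher number from compound 2 to compound 4 (0.07 log units; within the scatter)), so an aromatic ring at this carbon can do as well as piperidin-1-yl. Nothing available here explains why these rings differ.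

The compounds shown leave open how other five-membered rings, such as 1H-imidazol-1-yl, would behave at this carbon. They also leave open whether a six-membered ring such as morpholin-4-yl or an open-chain dimethylamino group would keep the number as low as piperidin-1-yl does.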